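Oxadiazole series: side-chain swap from compound 3 to compound 4

The source may report more compounds than this note shows. Statements on the series, on what has been measured and on what is new or still open speak of the compounds shown alone.

Measured in an assay on HeLa cells for inhibition of sphingosine-1-phosphate transporter SPNS2 (Mus musculus), read by LC-MS, tested at 2 uM; a higher number here means more inhibition at the concentration tested (going by the name of the read-out), a lower number less inhibition:
compound 1 `CCCCCCCCCCc1ccc(-c2noc(CCCN)n2)cc1`: 67%
compound 2 `CCCCCCCCCCc1ccc(-c2noc([C@@H]3CCNC3)n2)cc1`: 62%
compound 3 `CCCCCCCCCCc1ccc(-c2noc([C@H](CCCCN)NC(C)=O)n2)cc1`: 40%

Compound 3 stands lowest of the three numbers. Its nearest neighbour is compound 2, and both gaps, a number 22 percentage points lower from compound 2 to compound 3 (beyond the scatter) and a number 27 percentage points lower from compound 1 to compound 3 (beyond the scatter), lie beyond the scatter, whereas a number 5 percentage points lower from compound 1 to compound 2 (within the scatter) does not. Compound 4 `CCCCCCCCCCc1ccc(-c2noc(CC(O)CN3CCCCC3)n2)cc1` carries 2-hydroxy-3-(piperidin-1-yl)propyl in place of 1-acetamido-5-aminopentyl on an aromatic carbon. The two steps that end at compound 3 bear on this change: both moves onto the 1-acetamido-5-aminopentyl group cost modestly, while the 3-aminopropyl and pyrrolidin-3-yl groups sit close to one another. Compound 4 leaves that group again for a shorter chain ending in a six-membered non-aromatic ring, so a modest recovery toward the earlier level is expected for compound 4, a number 18 percentage points higher from compound 3 to compound 4 (beyond the scatter). Compound 4 is estimated at 58%, within 40% to 75%.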

Compound 4, a percentage reported as inhibition, at one concentration (the size of the read-out at that concentration, not a potency): 2%
For compound 4 the middle estimate is 56 percentage points above the measured one; the measured number lies below the stated range.
By their numbers in this assay, from the lowest: compound 4; then compound 3; then compounds 2 and 1 (each within the scatter of the next).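

Within the data shown here, at this aromatic carbon, a number 38 percentage points lower from compound 3 to compound 4 (beyond the scatter) and a number 60 percentage points lower from compound 2 to compound 4 (beyond the scatter) and a number 65 percentage points lower from compound 1 to compound 4 (beyond the scatter) in this assay are all large, whereas the earlier steps were modest at most. The heavy-atom count is unchanged from compound 3, so that count alone does not separate the side chains, and compound 4 gives 2% despite keeping a chain nitrogen. No evidence in hand accounts for the loss.

Open, going by these compounds, is whether the loss tracks the hydroxyl or the piperidine ring: a 3-(piperidin-1-yl)propyl chain without the hydroxyl, or a 3-amino-2-hydroxypropyl chain without the ring, would separate the two.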